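A few compounds are considered here, and "the series" means these few. Any claim that something is new, unique, unknown or untested is made for them only; others in the source may bear on it.

Measured compounds:
compound 1 `Cc1nc(S(C)(=O)=O)ccc1Oc1ncnc(OC2CCN(C(=O)OC(C)C)CC2)c1F` gives 21 nM
compound 2 `Cc1nc(S(C)(=O)=O)ccc1Oc1ncnc(OC2CCN(C(=O)OC(C)(C)C(F)(F)F)CC2)c1F` gives 6.53 nM
compound 3 `Cc1nc(S(C)(=O)=O)ccc1Oc1ncnc(OC2CCN(C(=O)OC(C)(C)C#N)CC2)c1F` gives 92.9 nM

All three numbers come from a functional assay on isolated protein for inhibition of Glucose-dependent insulinotropic receptor (Homo sapiens), read by HTRF and cAMP accumulation; on this read-out lower numbers stand for an effect already at smaller amounts and higher numbers for an effect only at larger amounts of compound. Compound 2 stands lowest of the three: a 3.2-fold lower number from compound 1 to compound 2 (0.51 log units; beyond the scatter), and a 14-fold higher number from compound 2 to compound 3 (1.15 log units; beyond the scatter). Compound 4 `Cc1nc(S(C)(=O)=O)ccc1Oc1ncnc(OC2CCN(C(=O)OC(C)(C)CF)CC2)c1F` differs from compound 2 in one place only: fluoromethyl in place of trifluoromethyl on a saturated chain carbon bound to an oxygen next to a carbonyl group and two saturated chain carbons. For the measured compounds named here, two measured steps bear on this change, both made at the same place: the step from hydrogen to trifluoromethyl, a 3.2-fold lower number from compound 1 to compound 2 (0.51 log units; beyond the scatter), and the step from hydrogen to cyano, a 4.4-fold higher number from compound 1 to compound 3 (0.65 log units; beyond the scatter). Compound 4 keeps one fluorine where compound 2 carries three, so its number is expected to lie between compound 1 and compound 2. The step of a 1.8-fold higher number from compound 2 to compound 4 (0.26 log units; within the scatter) is expected to be modest. Compound 4 is therefore estimated at 12 nM, within 5 nM to 30 nM.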

Compound 4, half-maximal effective concentration: 19.9 nM
Compound 4: middle estimate off by 1.7-fold (0.22 log units), on the low side; low and high end bracket the measured number.
By their numbers in this assay, from the lowest: compound 2; then compounds 4 and 1 (each within the scatter of the next); then compound 3.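

With fluoromethyl on this carbon, the number stays level with that for hydrogen (a 1.1-fold lower number from compound 1 to compound 4 (0.02 log units; within the scatter)), so a single fluorine does not reproduce what trifluoromethyl gives (a 3.0-fold higher number from compound 2 to compound 4 (0.48 log units; beyond the scatter)). Fluoromethyl also keeps the number clear of the one seen with cyano (a 4.7-fold lower number from compound 3 to compound 4 (0.67 log units; beyond the scatter)), which shows that not every replacement of hydrogen at this place behaves alike. Nothing available here explains these differences. Open, as far as these compounds go, is whether difluoromethyl would stand with trifluoromethyl or with fluoromethyl, and how a methoxy group or a longer chain such as ethyl would read.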